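From methoxy to hydroxy on compound 3

The compounds below may be only part of what the source reports. "The series", "measured", "known", "first", "only" and "open" are said of these compounds alone.

Of the compounds shown here, three have been measured in an ADME assay on HepG2 2.2.15 cells (Homo sapiens) for cytotoxicity, read by MTT assay, with stated times of 48 h and 9 days; a lower number here means that less compound is tolerated, a higher number that more compound is tolerated. Compound 1 `O=C(/C=C/c1coc2cc(O)ccc2c1=O)NCc1ccccc1` gives 436000 nM, and compound 2 `Cc1ccc(CNC(=O)/C=C/c2coc3cc(O)ccc3c2=O)cc1` gives 501000 nM. Compound 3 `COc1ccc2c(=O)c(/C=C/C(=O)NCc3ccc(F)cc3F)coc2c1` gives 79300 nM, the lowest of the three numbers, so the cells tolerate the least of it.

Compound 4 `O=C(/C=C/c1coc2cc(O)ccc2c1=O)NCc1ccc(F)cc1F` differs from compound 3 in one place, methoxy to hydroxy: hydrogen in place of methyl on an oxygen on an aromatic ring. Among the compounds with values here, no measured step covers this change. Within the data shown here, the only measured step, a 1.1-fold higher number from compound 1 to compound 2 (0.06 log units; within the scatter), lies elsewhere in the structure and bears on it only weakly. Compound 1 and compound 2 both carry the hydroxy and sit well above compound 3, but they also lack its fluorine substituents, so that gap cannot be credited to the hydroxy alone. Only part of the gap is therefore expected to appear, as a rise in this assay. The expected move is a 2.5-fold higher number from compound 3 to compound 4 (0.40 log units; beyond the scatter). In this assay the estimate for compound 4 is 200000 nM, with an expected range from 80000 nM to 500000 nM.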

Compound 4, half-maximal cytotoxic concentration: 470000 nM
The estimate for compound 4 lay 2.4-fold (0.37 log units) below the measured number, within the range that was stated.
By their numbers in this assay, from the lowest: compound 3; then compounds 1, 4 and 2 (each within the scatter of the next).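

Within the data shown here, replacing the methyl on this oxygen with hydrogen gives a 5.9-fold higher number from compound 3 to compound 4 (0.77 log units; beyond the scatter) in this assay, the first measured step at this position, and it shows that this small change can matter here. With the hydroxy in place, the ring on the amide side matters far less: 2,4-difluorophenyl in place of phenyl gives a 1.1-fold higher number from compound 1 to compound 4 (0.03 log units; within the scatter) and in place of 4-methylphenyl gives a 1.1-fold lower number from compound 2 to compound 4 (0.03 log units; within the scatter) in the same assay. Nothing here offers an explanation for the size of the step at the oxygen.

On these data alone, this methoxy to hydroxy step rests on a single pair, so it remains open whether it would be the same with phenyl or 4-methylphenyl on the amide side. Also open, as far as these compounds go, is how an ethoxy group or an amine would behave at this position.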